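Replacing phenyl with benzamidomethyl on the shared core

A few compounds are considered here, and "the series" means these few. Any claim that something is new, unique, unknown or untested is made for them only; others in the source may bear on it.

In a functional assay on HeLa cells (Homo sapiens) for inhibition, read by MTT assay, with a stated time of 72 h (a lower number here means a stronger inhibitor, a higher number a weaker inhibitor), compound 3 `c1ccc(-c2nnc(SCCCN3CCN(c4nc5ccccc5s4)CC3)o2)cc1` gives 229000 nM. Compound 2 `CC(C)(C)Oc1ccc(-c2nnc(SCCCN3CCN(c4nc5ccccc5s4)CC3)o2)cc1` gives 217000 nM, and the difference, a 1.1-fold higher number from compound 2 to compound 3 (0.02 log units; within the scatter), does not separate the two. Compound 1 `O=[N+]([O-])c1ccc(-c2nnc(SCCCN3CCN(c4nc5ccccc5s4)CC3)o2)cc1` gives 97800 nM, which stands apart from both: a 2.2-fold higher number from compound 1 to compound 2 (0.35 log units; beyond the scatter), and a 2.3-fold higher number from compound 1 to compound 3 (0.37 log units; beyond the scatter).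

Compound 4 `O=C(NCc1nnc(SCCCN2CCN(c3nc4ccccc4s3)CC2)o1)c1ccccc1` carries benzamidomethyl in place of phenyl on an aromatic carbon of a five-membered aromatic ring with 2 nitrogen and 1 oxygen, (benzamidomethyl in place of phenyl on an aromatic carbon). Among the measured compounds shown here, none of the measured steps makes this exchange. They only swap nitro, tert-butoxy and hydrogen on an aromatic carbon, so they offer indirect guidance. Even the step of a 2.3-fold higher number from compound 1 to compound 3 (0.37 log units; beyond the scatter) is modest, so in this assay no change beyond the scatter is expected, with only a slight lean towards a lower number. The expected step is a 1.2-fold lower number from compound 3 to compound 4 (0.08 log units; within the scatter). For compound 4 the estimated value is 190000 nM, with an expected range from 80000 nM to 450000 nM.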

Compound 4, half-maximal inhibitory concentration: 78100 nM
Beside the measured number, compound 4's estimate is 2.4-fold (0.39 log units) above it; the measured number lies below the stated range.
By their numbers in this assay, from the lowest: compounds 4 and 1 (each within the scatter of the next); then compounds 2 and 3 (each within the scatter of the next).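

The earlier steps shown here only changed what sits on the phenyl group, whereas this one replaces the whole phenyl group on the five-membered aromatic ring, and in this assay it gives a 2.9-fold lower number from compound 3 to compound 4 (0.47 log units; beyond the scatter). Exchanging the larger 4-(tert-butoxy)phenyl group for benzamidomethyl moves the number similarly, with a 2.8-fold lower number from compound 2 to compound 4 (0.44 log units; beyond the scatter), so this position tolerates a group that is not directly aromatic at the point of attachment and that brings in an amide hydrogen and a carbonyl. The gain does not set benzamidomethyl apart from 4-nitrophenyl, however, since a 1.3-fold lower number from compound 1 to compound 4 (0.10 log units; within the scatter).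

No evidence here shows whether the amide or its attached aromatic ring accounts for the lower number. From the compounds shown here alone, it also remains open how an amine, a carboxylic acid or the longer benzamidoethyl chain would behave at this position.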